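A few compounds are considered here, and "the series" means these few. Any claim that something is new, unique, unknown or untested is made for them only; others in the source may bear on it.

Three compounds share one core and differ only in the group attached to the amine nitrogen of the six-membered ring. In a functional assay on CHO-K1 cells for agonist activity at Glucose-dependent insulinotropic receptor (Homo sapiens), read by HTRF and cAMP accumulation, with a stated time of 30 min (on this read-out higher numbers stand for larger maximal responses and lower numbers for smaller maximal responses), compound 1 `CCc1cnc(N2CCC(CCCNc3ccc4c(c3)OCC4=O)CC2)nc1` gives 115%, compound 2 `COc1cnc(N2CCC(CCCNc3ccc4c(c3)OCC4=O)CC2)nc1` gives 101%, and compound 3 `CC(C)c1noc(N2CCC(CCCNc3ccc4c(c3)OCC4=O)CC2)n1` gives 94%. Compound 3 therefore holds the lowest of the three numbers, but its gap to compound 2 is within the scatter, so only compound 1 stands clearly apart from it: a number 21 percentage points lower from compound 1 to compound 3 (beyond the scatter) and a number 7 percentage points lower from compound 2 to compound 3 (within the scatter).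

Compound 4 `CC(C)c1nnc(N2CCC(CCCNc3ccc4c(c3)OCC4=O)CC2)o1` is built from compound 3 by rearranging the same atoms within the five-membered ring: 5-isopropyl-1,3,4-oxadiazol-2-yl in place of 3-isopropyl-1,2,4-oxadiazol-5-yl on an amine nitrogen in a ring. For the measured compounds named here, no measured step swaps one oxadiazole isomer for another, so no direct precedent exists. Going by the values given here, the only steps that touch this part of the molecule, from compound 1 to compound 3 and from compound 2 to compound 3, exchange a pyrimidine for the oxadiazole; those are different changes, and the second of them sits within the scatter. The change here keeps the ring size, the isopropyl group and the counted acceptors, so in this assay no step beyond the scatter is expected: no change at the digits printed from compound 3 to compound 4 (within the scatter). Compound 4 is therefore expected to give about 94%, within a range from 78% to 110%.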

Compound 4, largest response reached (Emax), in percent of the reference or control that the assay uses: 85%
Compound 4: the middle estimate sits 9 percentage points above what was measured; the range from low to high includes it.
By their numbers in this assay, from the lowest: compounds 4, 3 and 2 (each within the scatter of the next, the first and the last beyond it); then compound 1.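

In this assay, rearranging the atoms of the five-membered ring while keeping the isopropyl group and the counted acceptors gives a number 9 percentage points lower from compound 3 to compound 4 (within the scatter), so the two oxadiazole isomers cannot be told apart on this read-out. The new isomer does add one thing at this amine nitrogen: compound 3 stayed within the scatter of compound 2, yet the 5-isopropyl-1,3,4-oxadiazol-2-yl group shows a number 16 percentage points lower from compound 2 to compound 4 (beyond the scatter), and the largest gap in the set appears as a number 30 percentage points lower from compound 1 to compound 4 (beyond the scatter). Nothing available here accounts for these differences.

The compounds shown leave open how much of the gap to compound 1 belongs to the ring and how much to its substituent: ethyl and methoxy appear only on pyrimidines and isopropyl only on oxadiazoles, and a 5-isopropylpyrimidin-2-yl group or an ethyl-bearing oxadiazole would separate the two. Also open, from the compounds shown here alone, is how a non-aromatic group on the same nitrogen, such as a carbamate or an amide, would compare with these aromatic rings.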